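Moving the oxygen within a cyclobutyl side chain

This account rests on a few compounds, and the source may have more. Where it says the series, first, only, none or still open, it means among the compounds named here.

Compound 1 `CC(C)(CCCCF)[C@H](O)/C=C/[C@H]1COC(=O)N1CCSc1nc(C(=O)O)cs1`: 5.7 nM
Compound 2 `CCOCCC1([C@H](O)/C=C/[C@H]2COC(=O)N2CCSc2nc(C(=O)O)cs2)CCC1`: 29 nM

In an assay on isolated protein for agonist activity at prostaglandin E2 receptor EP2 subtype (Homo sapiens) (on this read-out lower numbers stand for an effect already at smaller amounts and higher numbers for an effect only at larger amounts of compound), compound 2 gives 29 nM, the highest of the two numbers. Within the data shown here, compound 1 gives 5.7 nM, and the only measured step is a 5.1-fold higher number from compound 1 to compound 2 (0.71 log units; beyond the scatter). Compound 3 `COCCCC1([C@H](O)/C=C/[C@H]2COC(=O)N2CCSc2nc(C(=O)O)cs2)CCC1` is compound 2 with methoxymethyl in place of ethoxy on a saturated chain carbon, two bonds along the chain from a saturated ring carbon. The measured step exchanged the whole side chain, so it says little about moving an oxygen within a chain built from the same atoms. Among the measured compounds shown here, with no step of that kind measured, a change within the scatter is expected. Compound 3 is estimated at 29 nM, between 10 nM and 90 nM. That expectation amounts to no change at the digits printed from compound 2 to compound 3 (within the scatter).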

Compound 3, half-maximal effective concentration: 18 nM
For compound 3 the middle estimate is 1.6-fold (0.21 log units) above the measured one; the range from low to high includes it.
By their numbers in this assay, from the lowest: compound 1; then compounds 3 and 2 (each within the scatter of the next).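

The step of a 1.6-fold lower number from compound 2 to compound 3 (0.21 log units; within the scatter) shows that in this assay moving the oxygen along the side chain, from 2-ethoxyethyl to 3-methoxypropyl, makes no difference beyond the scatter. The step of a 3.2-fold higher number from compound 1 to compound 3 (0.50 log units; beyond the scatter) shows that the new chain, like the 1-(2-ethoxyethyl)cyclobutyl chain, remains separated from the 5-fluoro-1,1-dimethylpentyl chain of compound 1. Nothing shown here gives a reason for either step.

Still open, going by these compounds, is whether the oxygen matters at all: a plain all-carbon chain, or an amine in its place, could answer that on the same cyclobutyl.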